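Azole and pyrrolidine variants on the acetamide arm

A few compounds are considered here, and "the series" means these few. Any claim that something is new, unique, unknown or untested is made for them only; others in the source may bear on it.

Measured so far:
compound 1 `C[C@@H]1CN(c2sc(C(F)(F)F)nc2-c2nc3ccccc3[nH]2)CCN1C(=O)Cn1ccc(C(=O)O)n1` 2100 nM
compound 2 `COC1CCN(CC(=O)N2CCN(c3sc(C(F)(F)F)nc3-c3nc4ccccc4[nH]3)C[C@H]2C)C1` 42 nM
compound 3 `Cc1nc(C)n(CC(=O)N2CCN(c3sc(C(F)(F)F)nc3-c3nc4c(F)cccc4[nH]3)C[C@H]2C)n1` 3.1 nM

In a functional assay on CHO-K1 cells for antagonist activity at C-X-C chemokine receptor type 3 (Homo sapiens), read by FLIPR, with a stated time of 10 min, in the presence of a further agent that is not named here (on this read-out lower numbers stand for stronger inhibition and higher numbers for weaker inhibition), compound 2 gives 42 nM, the second highest of the three numbers. Going by the values given here, the only single-point step recorded is a 50-fold lower number from compound 1 to compound 2 (1.70 log units; beyond the scatter), where 3-methoxypyrrolidin-1-yl replaces 3-carboxy-1H-pyrazol-1-yl on a saturated chain carbon bound to a carbonyl carbon. Compound 3 differs from compound 2 in two places; compound 3 gives 3.1 nM. It is not a single step, so it only shows that an aromatic azole on that chain carbon, together with a fluorinated core, sits at the low end of the numbers seen.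

Compound 4 `Cc1nn(CC(=O)N2CCN(c3sc(C(F)(F)F)nc3-c3nc4ccccc4[nH]3)C[C@H]2C)cc1CN(C)C` is the next variant: 4-((dimethylamino)methyl)-3-methyl-1H-pyrazol-1-yl in place of 3-methoxypyrrolidin-1-yl on a saturated chain carbon bound to a carbonyl carbon. Among the compounds with values here, no measured step covers exactly this exchange. The pair compound 1 to compound 2 shows that the group on this chain carbon can move the number strongly, and compound 3 shows that an azole there is compatible with a low number. Compound 4 is therefore expected to land below compound 2, with a 4.2-fold lower number from compound 2 to compound 4 (0.62 log units; beyond the scatter) estimated as the step, and a value of about 10 nM, within 2.5 nM to 60 nM.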

Compound 4, half-maximal inhibitory concentration: 2.7 nM
Beside the measured number, compound 4's estimate is 3.7-fold (0.57 log units) above it, and the stated range covers the measured number.
By their numbers in this assay, from the lowest: compounds 4 and 3 (each within the scatter of the next); then compound 2; then compound 1.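

Working notes on the chain carbon bound to the carbonyl carbon: in this assay the exchange of 3-methoxypyrrolidin-1-yl for 4-((dimethylamino)methyl)-3-methyl-1H-pyrazol-1-yl gives a 16-fold lower number from compound 2 to compound 4 (1.19 log units; beyond the scatter), so a substituted pyrazole at this place can go well beyond the pyrrolidine of compound 2 in a direct single-point comparison. Compound 1 and compound 4 both carry a 1H-pyrazol-1-yl ring here, and a 780-fold lower number from compound 1 to compound 4 (2.89 log units; beyond the scatter) shows that the ring alone does not fix the number: what hangs on the ring decides a very large part of the range seen so far. No measurement at hand accounts for either step.

The compounds shown do not separate the contribution of the methyl group from that of the (dimethylamino)methyl group on the pyrazole, and they do not show whether a pyrazole carrying only one of the two would keep the low number. Also open, going by these compounds, is how the number responds when the dimethylamino group is exchanged for a primary amine or a morpholine, or when a longer chain links that amine to the ring.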